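Swapping an ethyl for a methoxy on the outer ring

The source may report more compounds than this note shows. Statements on the series, on what has been measured and on what is new or still open speak of the compounds shown alone.

Compound 1 `CC[C@H](C)[C@H](N)CN(C(=O)[C@@H]1C[C@H]1c1nccs1)c1ccc(-c2ccccc2)cc1` gives 210 nM.
Compound 2 `CC(C)C[C@H](N)CN(C(=O)[C@@H]1C[C@H]1c1ccccc1)c1ccc(-c2cccc(C#N)c2)cc1` gives 4500 nM.
Compound 3 `CCc1ccc(-c2ccc(N(C[C@@H](N)[C@@H](C)CC)C(=O)[C@@H]3C[C@H]3c3ccccc3)cc2)cc1` gives 44 nM.

These three compounds were tested in a functional assay for agonist activity at G protein-coupled receptor 88 (Homo sapiens), read by HTRF and cAMP accumulation; on this read-out lower numbers stand for an effect already at smaller amounts and higher numbers for an effect only at larger amounts of compound. Compound 3 has the lowest number of the three; compound 1 sits closest to it, with a number beyond the usual scatter, and compound 2 lies furthest away. None of the three pairs differs in only one place, so no single change can be tied to a measured step.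

Compound 4 `CC[C@H](C)[C@H](N)CN(C(=O)[C@@H]1C[C@H]1c1ccccc1)c1ccc(-c2ccc(OC)cc2)cc1` is the next compound to be tested. It differs from compound 3 in one place: methoxy in place of ethyl on an aromatic carbon. Both groups are small, uncharged, and sit in the same spot on the outer ring; the methoxy brings one hydrogen-bond acceptor where the ethyl had none.

For the measured compounds named here, with no measured step of this kind to lean on, the expected step from compound 3 to compound 4 in this assay is a 1.8-fold higher number from compound 3 to compound 4 (0.26 log units; within the scatter), that is, a small shift toward a higher number that may well stay within the scatter. Compound 4 is therefore estimated at 80 nM, with a range from 25 nM to 300 nM.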

Compound 4, half-maximal effective concentration: 120 nM
The estimate for compound 4 lay 1.5-fold (0.18 log units) below the measured number; the measured number falls inside the stated range.
By their numbers in this assay, from the lowest: compound 3; then compounds 4 and 1 (each within the scatter of the next); then compound 2.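

Going from 4-ethylphenyl to 4-methoxyphenyl gives a 2.7-fold higher number from compound 3 to compound 4 (0.44 log units; beyond the scatter) in this assay, the first comparison in this set where only one place changes, and it shows that the number responds to what sits at this position on the outer ring. Ethyl and methoxy have the same count of heavy atoms, so a swap that keeps this count and adds one hydrogen-bond acceptor is enough to move the number beyond the scatter, with ethyl on the lower side. No measurement shown here explains why the number moves.

The compounds shown leave open how an amine, a chlorine atom or a longer chain such as propyl would fare at this position. They also leave open whether the same swap gives a similar step when other parts of the molecule differ.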